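A few compounds are considered here, and "the series" means these few. Any claim that something is new, unique, unknown or untested is made for them only; others in the source may bear on it.

Compound 1 `Cc1nnc(SCc2ccccc2)n1N1C(=O)c2ccccc2C1=O`: in a functional assay on A549 cells (Homo sapiens) for cytotoxicity, read by MTT assay, with a stated time of 48 h (a higher number here means a weaker inhibitor, a lower number a stronger inhibitor), compound 1 gives only a limit of the assay, > 200000 nM.
Compound 2 `Cc1nnc(SCC(=O)c2ccc(Cl)cc2)n1N1C(=O)c2ccccc2C1=O`: in this assay compound 2 gives only a limit of the assay, > 200000 nM.
Compound 3 `C#CCSc1nnc(C)n1N1C(=O)c2ccccc2C1=O`: in this assay compound 3 gives only a limit of the assay, > 200000 nM.

Compound 3 therefore stands nowhere in particular on the numbers shown: none of the three measured compounds has a number, all sit at the limit of > 200000 nM in this assay, at which 3 of the 3 values shown sit. The three steps among them, a step that the two limits leave unreadable from compound 1 to compound 2, a step that the two limits leave unreadable from compound 1 to compound 3 and a step that the two limits leave unreadable from compound 2 to compound 3, are unreadable for the same reason, since a change from one limit to another limit has no size.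

Compound 4 `Cc1nnc(SCc2ccccc2Cl)n1N1C(=O)c2ccccc2C1=O` differs from compound 3 by 2-chlorophenyl in place of ethynyl on a saturated chain carbon bound to a sulfur. Each of the measured steps bears on it only in that swapping the group on the saturated chain carbon bound to a sulfur, among a phenyl, a (4-chlorophenyl)carbonyl and an ethynyl, never produced a readable number in this assay. The expectation is therefore that compound 4 also gives only a limit, with a step that the limit leaves unreadable from compound 3 to compound 4 not readable beyond the scatter. The estimate for compound 4 is 250000 nM, with a range from 80000 nM to 800000 nM, and most likely reported as a limit.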

Compound 4, half-maximal inhibitory concentration: > 200000 nM
Compound 4 ended at the assay's limit (the forecaster's own chance of this, stated with the estimate: 85%); the middle value does not contradict the limit.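

Compound 4 gives only a limit of the assay, as do compound 1, compound 2 and compound 3, so none of the steps among these four compounds can be read: the limit of > 200000 nM in this assay, at which 4 of the 4 values shown sit.

The compounds shown leave open whether any group on the saturated chain carbon bound to a sulfur gives a readable number in this assay at all.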